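From Primary Amide to Hexyl Ester on a Shared Core

The source may hold more compounds than are shown below. What is called first, only, known or untested is meant among the compounds shown, and "the series" means these compounds.

Compound 1 `O=C(Nc1cc(Cl)cc(Cl)c1)c1cncnc1C(F)(F)F` gives > 10000 nM in an assay on Jurkat cells for inhibition of cyclic AMP-dependent transcription factor ATF-1 (Homo sapiens); a higher number here means a weaker inhibitor, a lower number a stronger inhibitor.
Compound 2 `NC(=O)c1cc(NC(=O)c2cnc(Cl)nc2C(F)(F)F)cc(C(F)(F)F)c1` gives 3000 nM in this assay.

Within the data shown here, only two compounds have been measured. Among the measured compounds shown here, for compound 1 the reported figure is a limit of the assay rather than a number, so it tells only that compound 1 is a weak inhibitor; (the limit of > 10000 nM in this assay, at which 1 of the 2 values shown sits). For the measured compounds named here, compound 2 therefore stands as the only compound with a numerical value in this assay, with nothing measured on either side of it.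

Compound 3 `CCCCCCOC(=O)c1cc(NC(=O)c2cnc(Cl)nc2C(F)(F)F)cc(C(F)(F)F)c1` differs from compound 2 in a single place: hexyloxy in place of amino on a carbonyl carbon. Going by the values given here, no two measured compounds differ in just one place, so no earlier step shows how large such a change tends to be. The step is expected to weaken inhibition somewhat, a 1.7-fold higher number from compound 2 to compound 3 (0.22 log units; within the scatter), and compound 3 is estimated at 5000 nM, with a range from 1500 nM to 20000 nM.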

Compound 3, half-maximal inhibitory concentration: 660 nM
Estimate against measurement, compound 3: 7.6-fold (0.88 log units) above; measured number below the stated range.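

In this assay, among these compounds, hexyloxycarbonyl in place of carbamoyl gives a 4.5-fold lower number from compound 2 to compound 3 (0.66 log units; beyond the scatter), the first change in a single place that can be read. On this carbonyl carbon, then, a hexyloxy group with its 7 heavy atoms can replace an amino group with 1, and the hydrogen-bond donor that amino carries is not needed for inhibition at the level of compound 2. Among the compounds shown here, nothing measured so far explains why the number falls.

The compounds shown leave open whether the change follows from the six-carbon chain or from the ester oxygen, and a methyl ester or a hexyl amide on the same core would help separate the two. On these data alone, how a carboxylic acid at this carbonyl carbon would compare also remains open.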